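Swapping a Cyclohexyl for a Trifluoromethylphenyl in Compound 3

The source may report more compounds than this note shows. Statements on the series, on what has been measured and on what is new or still open speak of the compounds shown alone.

Of the compounds shown here, three sharing one core have been tested in an assay on CCRF-CEM cells for displacement of a labelled ligand from C-C chemokine receptor type 4 (Homo sapiens); a higher number here means a weaker inhibitor, a lower number a stronger inhibitor. Compound 1 `CC(C)c1csc(Nc2cccc3ccccc23)n1` gives 170 nM. Compound 2 `NCc1csc(Nc2cccc3ccccc23)n1` reaches only the limit of the assay, > 25000 nM, so no number is known for it. Compound 3 `c1ccc2c(Nc3nc(CN(CC4CCCCC4)CC4CCCCC4)cs3)cccc2c1` gives 18 nM, the lowest of the two numbers, with compound 1 nearest to it. Going by the values given here, the one measured step, an at least 140-fold higher number from compound 1 to compound 2 (2.16 log units; beyond the scatter), concerns a group on an aromatic carbon of the shared core; its size is known only as a limit, (the limit of > 25000 nM in this assay, at which 1 of the 3 values shown sits), and it does not touch the part of the molecule that changes next.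

Compound 4 `FC(F)(F)c1ccccc1CN(Cc1csc(Nc2cccc3ccccc23)n1)CC1CCCCC1` differs from compound 3 in one place: 2-(trifluoromethyl)phenyl in place of cyclohexyl on a saturated chain carbon bound to an amine nitrogen. Among the compounds with values here, no measured step bears on this change, so the expectation rests on compound 3 alone, with the step from compound 3 to compound 4 in this assay expected to stay near the scatter, a 1.4-fold higher number from compound 3 to compound 4 (0.14 log units; within the scatter). Compound 4 is therefore estimated at 25 nM, within a range from 7 nM to 90 nM.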

Compound 4, half-maximal inhibitory concentration: 14 nM
The estimate for compound 4 lay 1.8-fold (0.25 log units) above the measured number; low and high end bracket the measured number.
By their numbers in this assay, from the lowest: compounds 4 and 3 (each within the scatter of the next); then compound 1. At a limit, above all of these: compound 2.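

In this assay, putting 2-(trifluoromethyl)phenyl in place of cyclohexyl on a saturated chain carbon bound to an amine nitrogen gives a 1.3-fold lower number from compound 3 to compound 4 (0.11 log units; within the scatter), so the two compounds cannot be told apart. Compound 3 alone showed only a non-aromatic ring of carbon at this place, whereas compound 4 shows that an aromatic ring bearing trifluoromethyl goes with an equally low number in this assay. Nothing available here accounts for why the two groups read alike.

A plain phenyl group would separate the part played by the aromatic ring from that of the trifluoromethyl group, and the compounds shown do not make that separation. Also open, from the compounds shown here alone, is how a ring carrying a carboxylic acid or an amine would read here, and whether the remaining cyclohexylmethyl group can be exchanged in the same way.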